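Ethoxy in Place of Methanesulfonamido: Expecting Compound 4

The source may report more compounds than this note shows. Statements on the series, on what has been measured and on what is new or still open speak of the compounds shown alone.

Compound 1, `Cn1c(-c2ccccc2C(F)(F)F)nnc1C12CCC(CNS(C)(=O)=O)(CC1)CC2`, in a functional assay on the whole organism (strain ICR) for inhibition, with Mus musculus as the target, with a stated time of 16 h, at a dose of 10 mg/kg by the oral route (a higher number here means more inhibition at the dose given (going by the name of the read-out), a lower number less inhibition), gives 27%.
Compound 2, `CCS(=O)(=O)CCC12CCC(c3nnc(-c4ccccc4Br)n3C)(CC1)CC2`, gives 65%.
Compound 3, `CCS(=O)(=O)CCCCC12CCC(c3nnc(-c4ccccc4C(F)(F)F)n3C)(CC1)CC2`, gives 58%.

Compound 1 stands lowest of the three numbers. Going by the values given here, its nearest neighbour is compound 3, which lies a number 31 percentage points higher from compound 1 to compound 3 (beyond the scatter), a step beyond the scatter; compound 2 lies further off still, and no single-point step connects it to compound 1.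

The unmeasured compound 4, `CCOCC12CCC(c3nnc(-c4ccccc4C(F)(F)F)n3C)(CC1)CC2`, differs from compound 1 in one place: ethoxy in place of methanesulfonamido on a saturated chain carbon bound to a saturated ring carbon. The step from compound 1 to compound 3 also removes the methanesulfonamido group from that same saturated chain carbon, putting 3-(ethylsulfonyl)propyl there, and it was large, a number 31 percentage points higher from compound 1 to compound 3 (beyond the scatter). Among the compounds with values here, only that one step bears directly on the present change, and the group entering here, ethoxy, is not the group that entered there, so the guidance is partial. Still, the one measured departure from methanesulfonamido at this position moved the inhibition upward, beyond the scatter.

Compound 4 is therefore expected to show an upward step, a number 18 percentage points higher from compound 1 to compound 4 (beyond the scatter), though smaller than the measured one, given the different entering group. The estimate for compound 4 in this assay is 45%, expected to fall between 22% and 68%.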

Compound 4, a percentage reported as inhibition, in the whole organism at one dose (the size of the read-out at that dose, not a potency): 3%
The estimate for compound 4 lay 42 percentage points above the measured number, and the stated range ends above it.
By their numbers in this assay, from the lowest: compound 4; then compound 1; then compounds 3 and 2 (each within the scatter of the next).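

In this assay, the saturated chain carbon bound to a saturated ring carbon proves able to move the number in both directions: ethoxy in place of methanesulfonamido gives a number 24 percentage points lower from compound 1 to compound 4 (beyond the scatter) and so runs opposite to the earlier change, which gave a number 31 percentage points higher from compound 1 to compound 3 (beyond the scatter) when 3-(ethylsulfonyl)propyl entered. Losing methanesulfonamido therefore does not by itself raise the inhibition, and the outcome here depends on the group that enters, as the comparison of the two entering groups confirms: ethoxy in place of 3-(ethylsulfonyl)propyl gives a number 55 percentage points lower from compound 3 to compound 4 (beyond the scatter) and is the largest of the steps at this place. Nothing at hand explains why these groups differ in this way.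

The compounds shown leave open whether the sulfonyl group or the length of the chain carries the higher numbers, and a simple propyl chain or an ethylsulfonylmethyl group at this place would bear on that question. They also leave open how an amine or a carboxylic acid would fare on the same chain carbon, with the rest of compound 1 unchanged.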